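Adding a Chlorine to the Benzyl Arm of Compound 3

A few compounds are considered here, and "the series" means these few. Any claim that something is new, unique, unknown or untested is made for them only; others in the source may bear on it.

Three compounds have been measured in a functional assay on the whole organism (artery, strain albino) with Rattus norvegicus as the target, with a stated time of 30 min, at a dose of 10 mg/kg by the oral route; a higher number here means more inhibition at the dose given (going by the name of the read-out), a lower number less inhibition:

Compound 1, `COc1ccc(C2N=C(SCc3ccccc3)NC(C)=C2C(=O)Nc2ccc(F)cc2)cc1OC`, gives 3.6%.
Compound 2, `COc1ccc(C2N=C(SCc3ccccc3Cl)NC(C)=C2C(=O)Nc2ccc(F)cc2)cc1OC`, gives 6.2%.
Compound 3, `CC1=C(C(=O)Nc2ccc(Br)cc2)C(c2ccc(Cl)cc2Cl)N=C(SCc2ccccc2)N1`, gives 3.6%.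

All three numbers are small and sit close together. Compound 3 stands level with compound 1 at the digits shown, and the two together are the lowest of the three; compound 2 lies a little higher, though the gap falls within the scatter of this assay.

Compound 4, `CC1=C(C(=O)Nc2ccc(Br)cc2)C(c2ccc(Cl)cc2Cl)N=C(SCc2ccc(Cl)cc2)N1`, has not yet been measured. It differs from compound 3 in one place: chloro in place of hydrogen on an aromatic carbon. Read one bond further out, the benzyl group becomes a 4-chlorobenzyl group.

Among the measured compounds shown here, one measured step bears on this change. Between compound 1 and compound 2 a chloro also replaced a hydrogen on an aromatic carbon, and the result was a number 2.6 percentage points higher from compound 1 to compound 2 (within the scatter). That step is within the scatter, so no shift beyond the scatter is expected here either. In this assay compound 4 is therefore expected to give 5%, within a range of -4% to 14%, which corresponds to an estimated step of a number 1.4 percentage points higher from compound 3 to compound 4 (within the scatter).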

Compound 4, a percentage reported as inhibition, in the whole organism at one dose (the size of the read-out at that dose, not a potency): 6.7%
Compound 4: middle estimate off by 1.7 percentage points, on the low side; measured number inside the range.
By their numbers in this assay, from the lowest: compounds 1, 3, 2 and 4 (each within the scatter of the next).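

Turning benzyl into 4-chlorobenzyl gives a number 3.1 percentage points higher from compound 3 to compound 4 (within the scatter) in this assay, so a chloro para to a large group on this ring also leaves the reading within the scatter. The earlier step came from a single pair of compounds, whereas this change has now been read on two different cores, and the two steps agree: the same change on two cores in this assay, a number 2.6 percentage points higher (within the scatter) from compound 1 to compound 2 and a number 3.1 percentage points higher (within the scatter) from compound 3 to compound 4, 0.5 percentage points apart, within the scatter of two such steps. Neither step lies beyond the scatter, so these compounds do not show that the chloro changes inhibition in this assay at all.

Going by these compounds, it remains open whether any group at this place on the ring can move the number beyond the scatter, for example an amine or a carboxylic acid in place of the chloro. Whether the small size of these steps would hold on other cores is also unknown.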